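Thiophene in place of triflate on the shared core

The source may report more compounds than this note shows. Statements on the series, on what has been measured and on what is new or still open speak of the compounds shown alone.

Compound 1 `Cc1[nH]c2ccccc2c1C1=CCNCC1` carries the shared core with hydrogen at the position of interest, and in an assay on HEK293 cells for displacement of a labelled ligand from 5-hydroxytryptamine receptor 6 (Homo sapiens), read by scintillation counting, with a stated time of 1 h (a lower number here means a stronger inhibitor, a higher number a weaker inhibitor), compound 1 gives 200 nM. Compound 2 `Cc1[nH]c2ccc(OS(=O)(=O)C(F)(F)F)cc2c1C1=CCNCC1` bears a ((trifluoromethyl)sulfonyl)oxy group on an aromatic carbon of the six-membered carbon-only ring, and in this assay compound 2 gives 50 nM. Going by the values given here, the step of a 4.0-fold lower number from compound 1 to compound 2 (0.60 log units; beyond the scatter) is the only measured step so far. Among the compounds with values here, of the two numbers available, compound 2 holds the lower one, with compound 1 as its sole neighbour at a gap beyond the scatter.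

Compound 3 `Cc1[nH]c2ccc(-c3ccsc3)cc2c1C1=CCNCC1` differs from compound 2 in one place: thiophen-3-yl in place of ((trifluoromethyl)sulfonyl)oxy on an aromatic carbon. Within the data shown here, no measured step exchanges one substituent for another at this carbon; the only step that bears on the position, a 4.0-fold lower number from compound 1 to compound 2 (0.60 log units; beyond the scatter), shows that a substituent there gave a lower number than hydrogen. Since compound 2 already carries a substituent, a smaller movement than that step is expected, and it may fall within the scatter. Compound 3 is therefore expected near 30 nM, with a range of 8 nM to 120 nM. The expected step is a 1.7-fold lower number from compound 2 to compound 3 (0.22 log units; within the scatter).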

Compound 3, half-maximal inhibitory concentration: 700 nM
Estimate against measurement, compound 3: 23-fold (1.37 log units) below; measured number outside the range, above it.
By their numbers in this assay, from the lowest: compound 2; then compound 1; then compound 3.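

The position does not reward every substituent: thiophen-3-yl reverses the direction seen with ((trifluoromethyl)sulfonyl)oxy, giving in this assay a 3.5-fold higher number from compound 1 to compound 3 (0.54 log units; beyond the scatter), against a 4.0-fold lower number from compound 1 to compound 2 (0.60 log units; beyond the scatter) for the earlier replacement of the same hydrogen. The identity of the group on this aromatic carbon therefore matters strongly, as the exchange of one substituent for the other gives a 14-fold higher number from compound 2 to compound 3 (1.15 log units; beyond the scatter), a large step and a wider separation than either group shows from hydrogen. No measurement here accounts for this reversal.

With only two substituents at this carbon, the differences between them cannot be separated: the group that leaves has 8 heavy atoms and no ring, while the group that enters has 5 heavy atoms in a five-membered aromatic ring. Still open, on these data alone, is where a methoxy group, a phenyl ring, an amine or a carboxylic acid on this carbon would fall relative to compound 2 and compound 3, and whether thiophen-2-yl would track thiophen-3-yl.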